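The compounds below may be only part of what the source reports. "The series", "measured", "known", "first", "only" and "open" are said of these compounds alone.

Measured compounds in a functional assay on DU-145 cells (Homo sapiens) for cytotoxicity, read by sulforhodamine B assay, with a stated time of 2 days, tested at 100 uM; a lower number here means less inhibition, a higher number more inhibition at the concentration tested (going by the name of the read-out):
Compound 1 `O=C(Nn1c(-c2cccc([N+](=O)[O-])c2)nc2c(-c3ccc(Cl)cc3)n[nH]c2c1=O)c1cccnc1` gives 31%.
Compound 2 `O=C(Nn1c(-c2cccc([N+](=O)[O-])c2)nc2c(-c3ccc(F)cc3)n[nH]c2c1=O)c1cccnc1` gives 24.9%.
Compound 3 `COc1cccc(-c2nc3c(-c4ccc(C5CCNCC5)cc4)n[nH]c3c(=O)n2NC(=O)c2ccncc2)c1` gives 37%.

Compound 2 stands lowest of the three numbers in this assay; compound 1 sits nearest, within the scatter, and compound 3 sits furthest, beyond the scatter. Within the data shown here, the one measured step that touches the same ring, a number 6.1 percentage points lower from compound 1 to compound 2 (within the scatter), lies within the scatter.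

Compound 4 `O=C(Nn1c(-c2cccc([N+](=O)[O-])c2)nc2c(-c3ccco3)n[nH]c2c1=O)c1cccnc1` differs from compound 2 by furan-2-yl in place of 4-fluorophenyl on an aromatic carbon. Among the measured compounds shown here, no measured step exchanges the six-membered ring for a five-membered one, so the only guidance is that a halogen swap at this place moved little. The step is therefore expected to be small, and compound 4 is estimated at 27% (range 10% to 45%), an expected step of a number 2.1 percentage points higher from compound 2 to compound 4 (within the scatter).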

Compound 4, a percentage reported as inhibition, at one concentration (the size of the read-out at that concentration, not a potency): 1.66%
Estimate against measurement, compound 4: 25.3 percentage points above; the whole stated range lies above it.
By their numbers in this assay, from the lowest: compound 4; then compounds 2, 1 and 3 (each within the scatter of the next, the first and the last beyond it).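

In this assay, this aromatic carbon proves sensitive to the identity of the ring it carries, which the halogen exchange did not reveal: furan-2-yl in place of 4-fluorophenyl gives a number 23.2 percentage points lower from compound 2 to compound 4 (beyond the scatter), and furan-2-yl in place of 4-chlorophenyl gives a number 29.3 percentage points lower from compound 1 to compound 4 (beyond the scatter). Both steps lie beyond the scatter, so at this position, exchanging the whole ring counts for more than exchanging the halogen. No measurement bears on the reason for this fall. From the compounds shown here alone, whether it follows the smaller ring or the ring oxygen remains open. A thiophen-2-yl group at this carbon would separate the two.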